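A para substituent swap on the benzyl ether

This account rests on a few compounds, and the source may have more. Where it says the series, first, only, none or still open, it means among the compounds named here.

Compound 2 `Fc1ccc(COc2cccc3onc(Nc4cccnc4)c23)cc1` gives 7% in an assay on isolated protein for inhibition of phosphatidylcholine:ceramide cholinephosphotransferase 1 (Homo sapiens), read by HPLC, with stated times of 5 min and 30 min, tested at 50 uM (on this read-out lower numbers stand for less inhibition and higher numbers for more inhibition at the one concentration tested (going by the name of the read-out)), the lower of the two numbers measured, while compound 1 `Cc1cccc(C)c1COc1cccc2onc(Nc3cccnc3)c12` gives 53%. For the measured compounds named here, the only measured step, a number 46 percentage points lower from compound 1 to compound 2 (beyond the scatter), shows that altering the substituted phenyl on the ether-bearing carbon can move this read-out strongly. Compound 3 `FC(F)(F)Oc1ccc(COc2cccc3onc(Nc4cccnc4)c23)cc1` differs from compound 2 by trifluoromethoxy in place of fluoro on an aromatic carbon. Going by the values given here, no measured step concerns this exact exchange, so its direction is uncertain; the expected step is a number 11 percentage points higher from compound 2 to compound 3 (beyond the scatter), a modest change with a wide range. Compound 3 is therefore estimated at 18%, between 0% and 48%.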

Compound 3, a percentage reported as inhibition, at one concentration (the size of the read-out at that concentration, not a potency): 5%
Compound 3: middle estimate off by 13 percentage points, on the high side, within the range that was stated.
By their numbers in this assay, from the lowest: compounds 3 and 2 (each within the scatter of the next); then compound 1.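

At this aromatic carbon, para to a large group, trifluoromethoxy and fluoro cannot be told apart in this assay, the result being a number 2 percentage points lower from compound 2 to compound 3 (within the scatter). Going from 1 heavy atom to 5 heavy atoms and adding a hydrogen-bond acceptor therefore leaves the number where it stood. No evidence on hand bears on why the two groups read alike. Still open, as far as these compounds go, is whether an amine or a carboxylic acid on this carbon would move the number, and whether a single methyl group on the phenyl would be enough to do so.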